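The compounds below may be only part of what the source reports. "The series", "measured", "known", "first", "only" and "open" are said of these compounds alone.

Compound 1 `Cc1[nH]c2ccccc2c1C1CC(c2ccncc2)=NO1`: > 100000 nM
Compound 2 `Clc1ccc(Cn2cc(C3CC(c4ccncc4)=NO3)c3ccccc32)cc1`: 10200 nM
Compound 3 `COc1ccc2c(C3CC(c4ccncc4)=NO3)c[nH]c2c1`: 4160 nM

In a functional assay on HEK293 cells (Homo sapiens) for inhibition, read by MTT assay, with a stated time of 48 h (on this read-out lower numbers stand for stronger inhibition and higher numbers for weaker inhibition), compound 1 reaches (the limit of > 100000 nM in this assay, at which 1 of the 3 values shown sits), which is a limit of the assay and not a number. Compound 2 gives 10200 nM in this assay, while compound 3 gives 4160 nM, the lowest of the two numbers and beyond the scatter from compound 2. Compound 4 `c1ccc2c(C3CC(c4ccncc4)=NO3)c[nH]c2c1` differs from compound 3 by hydrogen in place of methoxy on an aromatic carbon. Among the measured compounds shown here, no measured pair here shows a change of this kind, so its size is not known from the data. In this assay a modest step toward a higher number, or none beyond the scatter, is expected for compound 4. Compound 4 is thus estimated at 7000 nM, with a range from 2500 nM to 25000 nM. The expected step is a 1.7-fold higher number from compound 3 to compound 4 (0.23 log units; within the scatter).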

Compound 4, half-maximal inhibitory concentration: > 100000 nM
Compound 4: a limit, no number (the forecaster's own chance of this, stated with the estimate: 15%); middle value at least 14-fold (1.15 log units) from the limit.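

In this assay hydrogen in place of methoxy on the aromatic carbon gives an at least 24-fold higher number from compound 3 to compound 4 (1.38 log units; beyond the scatter) and hydrogen in place of 4-chlorobenzyl on the aromatic nitrogen gives an at least 9.8-fold higher number from compound 2 to compound 4 (0.99 log units; beyond the scatter), so either group alone separates a measured number from the limit. Compound 4 stands at a limit of the assay, not a number: the limit of > 100000 nM in this assay, at which 2 of the 4 values shown sit. The step linking compound 1 and compound 4 cannot be read, as both values are limits. On these data alone, whether a hydroxyl or an amine on this aromatic carbon would keep a measurable number stays open. So does whether methoxy and 4-chlorobenzyl together would lower the number further.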